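This account rests on a few compounds, and the source may have more. Where it says the series, first, only, none or still open, it means among the compounds named here.

Within the data shown here, in an ADME assay on HepG2 2.2.15 cells (Homo sapiens) for cytotoxicity, read by MTT assay (on this read-out lower numbers stand for higher toxicity in this test and higher numbers for lower toxicity in this test), three compounds have numbers so far. Compound 1 (`C=C1CC[C@@H]2[C@](C)(COC(=O)/C=C/c3ccccc3)[C@H](O)CC[C@@]2(C)[C@@H]1/C=C/C1=CCOC1=O`) gives 183000 nM, compound 2 (`C=C1CC[C@@H]2[C@](C)(COC(=O)c3cccs3)[C@H](O)CC[C@@]2(C)[C@@H]1/C=C/C1=CCOC1=O`) gives 557000 nM, and compound 3 (`C=C1CC[C@@H]2[C@](C)(COC(=O)/C=C/c3ccccc3)[C@H](O)CC[C@@]2(C)[C@@H]1C/C=C1\C=COC1=O`) gives 271000 nM. Compound 3 thus lies within the scatter of compound 1, while compound 2 has the highest number of the three, clear of both.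

The unmeasured compound 4 (`C=C1CC[C@@H]2[C@](C)(COC(=O)c3cccs3)[C@H](O)CC[C@@]2(C)[C@@H]1C/C=C1\C=COC1=O`) differs from compound 3 in one place: thiophen-2-yl in place of 2-phenylethenyl on a carbonyl carbon. In words, this is thiophen-2-yl in place of 2-phenylethenyl on a carbonyl carbon. The same exchange has a single precedent, a 3.0-fold higher number from compound 1 to compound 2 (0.48 log units; beyond the scatter), a modest step beyond the scatter. The other measured step, a 1.5-fold higher number from compound 1 to compound 3 (0.17 log units; within the scatter), stays within the scatter, and it is the difference that also separates compound 2 from compound 4. A step of similar size and the same direction is therefore expected, though it rests on one pair only. The expected step is a 2.8-fold higher number from compound 3 to compound 4 (0.44 log units; beyond the scatter). The estimate for compound 4 is 750000 nM, with an expected range from 380000 nM to 1500000 nM.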

Compound 4, half-maximal cytotoxic concentration: 2470000 nM
Compound 4: middle estimate off by 3.3-fold (0.52 log units), on the low side, and the stated range ends below it.
By their numbers in this assay, from the lowest: compounds 1 and 3 (each within the scatter of the next); then compound 2; then compound 4.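

The exchange of 2-phenylethenyl for thiophen-2-yl on the carbonyl carbon gives a 9.1-fold higher number from compound 3 to compound 4 (0.96 log units; beyond the scatter) in this assay, so the size of this change depends on the core that carries it: the same change on two cores in this assay, a 3.0-fold higher number (0.48 log units; beyond the scatter) from compound 1 to compound 2 and a 9.1-fold higher number (0.96 log units; beyond the scatter) from compound 3 to compound 4, 3.0-fold (0.48 log units) apart, beyond the scatter of two such steps

The other difference, on the saturated ring carbon, stayed within the scatter with 2-phenylethenyl on the carbonyl but clears it with thiophen-2-yl, at a 4.4-fold higher number from compound 2 to compound 4 (0.65 log units; beyond the scatter): the same change on two cores in this assay, a 1.5-fold higher number (0.17 log units; within the scatter) from compound 1 to compound 3 and a 4.4-fold higher number (0.65 log units; beyond the scatter) from compound 2 to compound 4, 3.0-fold (0.48 log units) apart, beyond the scatter of two such steps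

Across these four compounds, then, the two changes do not add independently.

The compounds shown leave open whether this interplay is particular to thiophen-2-yl or extends to other groups on the carbonyl carbon, such as a simple phenyl ring, an amine-bearing chain or a carboxylic acid. They also cannot tell what underlies the dependence on the core.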